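The source may hold more compounds than are shown below. What is called first, only, known or untested is meant among the compounds shown, and "the series" means these compounds.

Compound 1 `CCCCCc1ccc(NS(=O)(=O)c2ccc(N3CCNC3=O)cc2)cc1`: 990 nM in a functional assay on HT-29 cells (Homo sapiens) for antiproliferative activity, read by sulforhodamine B assay, with a stated time of 48 h; on this read-out higher numbers stand for weaker inhibition and lower numbers for stronger inhibition
Compound 2 `Cc1ccc(NS(=O)(=O)c2ccc(N3CCNC3=O)cc2)c(C)c1`: 180 nM in this assay

On these two numbers compound 2 stands at the lowest; its nearest neighbour is compound 1, whose number is higher by a margin beyond the scatter. Compound 3 `O=C1NCCN1c1ccc(S(=O)(=O)Nc2ccc(F)cc2)cc1` is not yet measured in this assay. It differs from compound 2 in one place: 4-fluorophenyl in place of 2,4-dimethylphenyl on a sulfonamide nitrogen. Among the measured compounds shown here, no measured pair in this set carries this change, so there is no direct precedent for it. A modest move toward a higher number is expected, a 2.2-fold higher number from compound 2 to compound 3 (0.35 log units; beyond the scatter), perhaps not beyond the scatter. Compound 3 is estimated at 400 nM, within a range from 100 nM to 1600 nM.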

Compound 3, half-maximal inhibitory concentration: 370 nM
Estimate against measurement, compound 3: 1.1-fold (0.03 log units) above; measured number inside the range.
By their numbers in this assay, from the lowest: compound 2; then compound 3; then compound 1.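

Two single changes on the aromatic ring can now be read in this assay: 4-fluorophenyl in place of 2,4-dimethylphenyl gives a 2.1-fold higher number from compound 2 to compound 3 (0.31 log units; beyond the scatter), and fluoro in place of pentyl gives a 2.7-fold lower number from compound 1 to compound 3 (0.43 log units; beyond the scatter). Both steps are modest, so among these three compounds, changing this group on the sulfonamide nitrogen shifts the number without abolishing activity. Nothing shown explains either step. From the compounds shown here alone, whether a chloro or methoxy group in place of fluoro would give a similar number remains open. So does the effect of an amine or a carboxylic acid on this ring.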